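Working notes: from carboxy to carboxymethyl

The source may report more compounds than this note shows. Statements on the series, on what has been measured and on what is new or still open speak of the compounds shown alone.

Measured in a functional assay (thoracic aorta) for inhibition, with Rattus norvegicus as the target; a lower number here means a stronger inhibitor, a higher number a weaker inhibitor:
- compound 1 `CC(C)c1ccc2c(CCCCNS(=O)(=O)c3ccccc3)cc(C(=O)O)c-2cc1`: 70 nM
- compound 2 `CC(C)c1ccc2c(CCCCNS(=O)(=O)c3cccc(C(F)(F)F)c3)cc(C(=O)O)c-2cc1`: 1600 nM

The lower of the two numbers in this assay belongs to compound 1. Compound 3 `CC(C)c1ccc2c(CCCCNS(=O)(=O)c3ccccc3)cc(CC(=O)O)c-2cc1` differs from it by one change: carboxymethyl in place of carboxy on an aromatic carbon. Among the measured compounds shown here, the only measured step, a 23-fold higher number from compound 1 to compound 2 (1.36 log units; beyond the scatter), is large but lies at a different place, so it shows only that single changes can matter here. For the measured compounds named here, no measurement yet tests the carboxy group. A moderate rise is expected, with low confidence: the estimated step is a 4.3-fold higher number from compound 1 to compound 3 (0.63 log units; beyond the scatter). For compound 3 the estimated value is 300 nM, with a range of 50 nM to 2000 nM.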

Compound 3, half-maximal inhibitory concentration: 300 nM
Compound 3: the middle estimate sits on the measured number at the digits printed, and the stated range covers the measured number.
By their numbers in this assay, from the lowest: compound 1; then compound 3; then compound 2.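

In this assay, carboxymethyl in place of carboxy gives a 4.3-fold higher number from compound 1 to compound 3 (0.63 log units; beyond the scatter). This position on the shared core is therefore not indifferent to the change, although inhibition persists with carboxymethyl. Nothing available accounts for the size of this step.

Still open, on these data alone, is how a longer chain ending in a carboxylic acid, or an amide or a tetrazole in place of the carboxy group, would read here. Also open, as far as these compounds go, is whether trifluoromethyl on the benzene of the sulfonamide would act the same way alongside carboxymethyl.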